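This account rests on a few compounds, and the source may have more. Where it says the series, first, only, none or still open, it means among the compounds named here.

Of the compounds shown here, three sharing one core have been tested in a functional assay (Oryctolagus cuniculus) for antagonist activity at platelet-activating factor receptor (Cavia porcellus); on this read-out lower numbers stand for stronger inhibition and higher numbers for weaker inhibition. Compound 1 `CCNC(=O)n1cc(C(=O)c2ccn3c2CSC3c2cccnc2)c2ccc(-c3ccc(F)cc3)cc21` gives 19 nM, compound 2 `NC(=O)n1cc(C(=O)c2ccn3c2CSC3c2cccnc2)c2ccc(-c3ccc(F)cc3)cc21` gives 6 nM, and compound 3 `CN(C)C(=O)Cn1cc(C(=O)c2ccn3c2CSC3c2cccnc2)c2ccc(-c3ccc(F)cc3)cc21` gives 0.7 nM, the lowest of the three numbers and thus the strongest inhibitor among them. The steps of an 8.6-fold lower number from compound 2 to compound 3 (0.93 log units; beyond the scatter) and a 27-fold lower number from compound 1 to compound 3 (1.43 log units; beyond the scatter) show that the group on the aromatic nitrogen changes the result a great deal. Compound 4 `O=C(O)CCn1cc(C(=O)c2ccn3c2CSC3c2cccnc2)c2ccc(-c3ccc(F)cc3)cc21` carries carboxymethyl in place of dimethylcarbamoyl on a saturated chain carbon bound to an aromatic nitrogen. For the measured compounds named here, no measured step brings a carboxymethyl into this position, so the earlier steps only show that changes here can be large. A somewhat weaker inhibition is expected for compound 4, a step of a 4.3-fold higher number from compound 3 to compound 4 (0.63 log units; beyond the scatter) in this assay. The estimate for compound 4 is 3 nM, between 0.7 nM and 15 nM.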

Compound 4, inhibition constant: 160 nM
For compound 4 the middle estimate is 53-fold (1.73 log units) below the measured one; the measured number lies above the stated range.
By their numbers in this assay, from the lowest: compound 3; then compound 2; then compound 1; then compound 4.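

In this assay, compound 4 is the weakest of the four inhibitors, with a 230-fold higher number from compound 3 to compound 4 (2.36 log units; beyond the scatter), a 27-fold higher number from compound 2 to compound 4 (1.43 log units; beyond the scatter) and an 8.4-fold higher number from compound 1 to compound 4 (0.93 log units; beyond the scatter). So this position does not accept every group: the swap removes 5 heavy atoms and brings in 4 with one hydrogen-bond donor, yet it gives the largest step seen here. Nothing available explains this loss.

Going by these compounds, it remains open whether the carboxylic acid or the longer chain matters more. A dimethylamide or a methyl ester on that same longer chain would separate the two.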